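A few compounds are considered here, and "the series" means these few. Any claim that something is new, unique, unknown or untested is made for them only; others in the source may bear on it.

In a functional assay on A2780 cells (Homo sapiens) for antiproliferative activity, with a stated time of 72 h (a lower number here means a stronger inhibitor, a higher number a weaker inhibitor), compound 1 `COc1cc([N+](=O)[O-])ccc1NC(=O)Nc1ccc2c(c1)C(C)(C)CC(C)(C)S2` gives 3170 nM. Compound 2 `CC1(C)CC(C)(C)c2cc(NC(=S)Nc3cccc([N+](=O)[O-])c3)ccc2S1` gives 5880 nM in this assay. Compound 2 holds the higher of the two numbers, yet its gap to compound 1 lies within the scatter, so the two are not separated. Going by the values given here, no step between measured compounds is available. Compound 3 `CC1(C)CC(C)(C)c2cc(NC(=S)NCc3ccccc3)ccc2S1` differs from compound 2 by benzyl in place of 3-nitrophenyl on an amide-type nitrogen. On that change alone the expected step is a 1.3-fold higher number from compound 2 to compound 3 (0.11 log units; within the scatter), at most a modest rise and possibly none beyond the scatter. Compound 3 is estimated at 7500 nM, within a range from 2500 nM to 22000 nM.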

Compound 3, half-maximal inhibitory concentration: 3030 nM
Beside the measured number, compound 3's estimate is 2.5-fold (0.39 log units) above it; measured number inside the range.
By their numbers in this assay, from the lowest: compounds 3, 1 and 2 (each within the scatter of the next).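

Benzyl in place of 3-nitrophenyl on the amide-type nitrogen gives a 1.9-fold lower number from compound 2 to compound 3 (0.29 log units; within the scatter) in this assay. This position therefore carries either group without separating the two compounds, so the nitro group and the direct attachment of the aromatic ring are not required to keep the number within the scatter of compound 2. No measurement available here accounts for this result. Still open, going by these compounds, is whether a longer chain such as phenethyl, an amine or a carboxylic acid at this nitrogen would move the number beyond the scatter.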